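The source may hold more compounds than are shown below. What is called first, only, known or untested is meant among the compounds shown, and "the series" means these compounds.

Compound 1 `COc1ccc(-c2nc(N=C(N)N)sc2-c2ccc(OC)cc2)cc1` carries a group of 4 heavy atoms (1 carbon, 3 nitrogen; no ring) on an aromatic carbon of its core, and in a functional assay (aorta) with Rattus norvegicus as the target (a lower number here means that less compound is needed, a higher number that more compound is needed for the effect), compound 1 gives 2 uM. Two measured companions vary that same group. Compound 2 `CNC(=N)Nc1nc(-c2ccc(OC)cc2)c(-c2ccc(OC)cc2)s1` gives 1.2 uM in this assay, and compound 3 `C/N=C(/NC)Nc1nc(-c2ccc(OC)cc2)c(-c2ccc(OC)cc2)s1` gives 2.4 uM. The three numbers sit close together: a 1.7-fold lower number from compound 1 to compound 2 (0.22 log units; within the scatter), a 1.2-fold higher number from compound 1 to compound 3 (0.08 log units; within the scatter), and a 2.0-fold higher number from compound 2 to compound 3 (0.30 log units; within the scatter). Compound 1 thus stands second highest of three, with none of the three apart beyond the scatter.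

Compound 4 `COc1ccc(-c2nc(CN(C)C)sc2-c2ccc(OC)cc2)cc1` is not yet measured in this assay. Its change from compound 1 is a group of 4 heavy atoms (3 carbon, 1 nitrogen; no ring) in place of a group of 4 heavy atoms (1 carbon, 3 nitrogen; no ring), on an aromatic carbon. The measured steps only swap carbon atoms on the nitrogens of the group that leaves; none of them removes that group or its two hydrogen-bond donors, so they bear on this change only loosely. With that gap in the data, a somewhat higher number is expected for compound 4, with wide uncertainty, as a 2.5-fold higher number from compound 1 to compound 4 (0.40 log units; beyond the scatter). Compound 4 is therefore estimated at 5 uM, within a range from 1.5 uM to 20 uM.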

Compound 4, concentration for half-maximal effect: 8.4 uM
Estimate against measurement, compound 4: 1.7-fold (0.23 log units) below; the range from low to high includes it.
By their numbers in this assay, from the lowest: compounds 2, 1 and 3 (each within the scatter of the next); then compound 4.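

Compared with the three guanidine-type groups, (dimethylamino)methyl on this aromatic carbon gives the first changes that lie beyond the scatter in this assay (a 4.2-fold higher number from compound 1 to compound 4 (0.62 log units; beyond the scatter); a 3.5-fold higher number from compound 3 to compound 4 (0.54 log units; beyond the scatter); a 7.0-fold higher number from compound 2 to compound 4 (0.85 log units; beyond the scatter)). The earlier steps shown here altered only the carbon atoms on the nitrogens of the group, whereas this change replaces the group itself, going from 2 hydrogen-bond donors to 0 and losing the double bond outside aromatic rings, so the position responds to the identity of the group and not only to its number of heavy atoms. Nothing measured here accounts for this shift.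

Because these features change together, the compounds shown do not tell which of them matters. An aminomethyl group, a simple amide or a piperidine ring at this carbon would show how far the number depends on the nitrogens of the group.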